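The source may hold more compounds than are shown below. What is called first, only, known or untested is meant among the compounds shown, and "the series" means these compounds.

Of the compounds shown here, three of a shared core have been measured in a functional assay on CHO-K1 cells for antagonist activity at adenosine receptor A1 (Homo sapiens), read by a beta-galactosidase reporter and cAMP accumulation, with stated times of 15 min and 6 h; on this read-out lower numbers stand for stronger inhibition and higher numbers for weaker inhibition. Compound 1 `Cc1ccc(-c2nc(N)c3ccsc3n2)o1` gives in this assay 493 nM. Within the data shown here, compound 2 `Nc1nc(-c2ncco2)nc2sc(Cc3ccccc3)cc12` gives in this assay 310 nM, a number that sits within the usual scatter of the one for compound 1, so the two cannot be told apart. Compound 3 `N#Cc1cccc(-c2nc(N)c3cc(Cc4ccccc4F)sc3n2)c1` is reported in this assay only as a limit, < 16 nM, and the value shown for it is no number but the edge of the assay; of the three values shown, this is the one that rests on (the limit of < 16 nM in this assay, at which 1 of the 3 values shown sits). No pair among these three differs in one place only, so no single step can be read off from them.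

Compound 4 `Nc1nc(-c2cccc(Cl)n2)nc2sc(Cc3ccccc3)cc12` has not yet been measured in this assay. It differs from compound 2 in a single change: 6-chloropyridin-2-yl in place of 1,3-oxazol-2-yl on an aromatic carbon. Among the measured compounds shown here, since no measured step carries this kind of change, the size of the step from compound 2 to compound 4 can only be estimated. Compound 3, whose aromatic group on the same position is six-membered, stays at the limit of the assay, and on that ground the expected step is a 5.2-fold lower number from compound 2 to compound 4 (0.71 log units; beyond the scatter), toward a lower number. Compound 4 is therefore expected to give in this assay about 60 nM, with a range from 15 nM to 250 nM.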

Compound 4, inhibition constant: > 1000 nM
Compound 4 was reported as a limit; the forecaster's own chance of this, stated with the estimate: 15%; middle value at least 16-fold (1.22 log units) away from the limit.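

Among these compounds, this is the first step that can be read at a single position, the aromatic carbon between two ring nitrogen atoms: with 6-chloropyridin-2-yl in place of 1,3-oxazol-2-yl, this assay shows an at least 3.2-fold higher number from compound 2 to compound 4 (0.50 log units; beyond the scatter) on the same benzyl-bearing core. Among the compounds shown here, the position therefore does not treat these two aromatic groups alike, and the change moves the read-out toward weaker inhibition, a direction that compounds 1, 2 and 3 could not reveal because no pair among them differs in one place. As far as these compounds go, the true size of the step remains unknown, since compound 4 is reported only as a limit: the limit of > 1000 nM in this assay, at which 1 of the 4 values shown sits.

The change replaces the five-membered ring with a six-membered one and brings in chlorine in a single move, so the compounds shown cannot assign the loss to either part. From the compounds shown here alone, whether pyridin-2-yl without the chlorine, or with a methyl or a methoxy group in its place, would read closer to compound 2 stays open.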